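The source may report more compounds than this note shows. Statements on the series, on what has been measured and on what is new or still open speak of the compounds shown alone.

Working notes on the series. In a functional assay on SH-SY5Y cells (Homo sapiens) for cytotoxicity, read by MTT assay, with a stated time of 72 h (on this read-out higher numbers stand for weaker inhibition and lower numbers for stronger inhibition), compound 1 `CN(C)CCCCCn1c2c(c3ccccc31)C(=O)c1c[n+]([O-])c3ccccc3c1C2=O` gives 370 nM and compound 2 `O=C1c2c[n+]([O-])c3ccccc3c2C(=O)c2c1c1ccccc1n2Cc1cn([C@H]2O[C@H](CO)[C@@H](O)[C@H]2O)nn1` gives 1340 nM. Compound 2 therefore holds the higher of the two numbers, meaning the weaker inhibition, and its gap to compound 1 lies beyond the scatter. These two differ across the whole side chain, so the gap says nothing about any single group.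

Compound 3 `O=C1c2c[n+]([O-])c3ccccc3c2C(=O)c2c1c1ccccc1n2Cc1cn([C@@H]2C[C@H](O)[C@@H](CO)O2)nn1` carries the change (hydrogen in place of hydroxy on a saturated ring carbon), with hydrogen in place of hydroxy on a saturated ring carbon. For the measured compounds named here, no measured pair isolates this change, so the expectation is loose and anchored on compound 2 at 1340 nM. A small step within the scatter is expected in this assay, with no firm direction and only a slight lean towards a lower number. The expected step is a 1.1-fold lower number from compound 2 to compound 3 (0.05 log units; within the scatter). For compound 3 the estimated value is 1200 nM, with an expected range of 450 nM to 3200 nM.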

Compound 3, half-maximal inhibitory concentration: 150 nM
The estimate for compound 3 lay 8.0-fold (0.90 log units) above the measured number, and the stated range ends above it.
By their numbers in this assay, from the lowest: compound 3; then compound 1; then compound 2.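

For the compounds shown here, the step of an 8.9-fold lower number from compound 2 to compound 3 (0.95 log units; beyond the scatter) in this assay is the first change that can be read at a single place, and it shows that this saturated ring carbon of the side chain is not indifferent to its substituent. Going from 3,4-dihydroxy-5-(hydroxymethyl)oxolan-2-yl to 4-hydroxy-5-(hydroxymethyl)oxolan-2-yl goes with stronger inhibition on this read-out, by a margin beyond the scatter. This reading rests on one pair alone.

On these data alone, whether a fluorine atom or a methoxy group on this ring carbon would read like hydrogen or like hydroxy remains open, as does the effect of changing the remaining hydroxy group or the hydroxymethyl group. No supporting evidence bears on why the step arises.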